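Trifluoroacetyl Amide on the Piperidine Nitrogen: Expected Efficacy

The compounds below may be only part of what the source reports. "The series", "measured", "known", "first", "only" and "open" are said of these compounds alone.

Two compounds of this series have a number in a functional assay on isolated protein for inhibition of Glucose-dependent insulinotropic receptor (Rattus norvegicus), read by HTRF and cAMP accumulation; on this read-out lower numbers stand for smaller maximal responses and higher numbers for larger maximal responses. Compound 1 `Cc1nc(S(C)(=O)=O)ccc1Oc1ncnc(OC2CCN(C(=O)O[C@H](C)CF)CC2)c1F` gives 79% in this assay. Within the data shown here, compound 2 `Cc1nc(S(C)(=O)=O)ccc1Oc1ncnc(OC2CCN(C(=S)OC(C)C)CC2)c1F` gives 47% in this assay, the lowest of the two numbers; the one step between them, a number 32 percentage points lower from compound 1 to compound 2 (beyond the scatter), is beyond the scatter and large.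

Compound 3 `Cc1nc(S(C)(=O)=O)ccc1Oc1ncnc(OC2CCN(C(=O)C(F)(F)F)CC2)c1F` differs from compound 2 by a group of 6 heavy atoms (2 carbon, 1 oxygen, 3 fluorine; no ring) in place of a group of 6 heavy atoms (4 carbon, 1 oxygen, 1 sulfur; no ring), on an amine nitrogen in a ring. The entering (trifluoromethyl)carbonyl sits on the amine nitrogen of the six-membered non-aromatic ring with 1 nitrogen, three ring bonds from the ring atom that bears a large group, the same place where compound 1 and compound 2 differ.

Among the measured compounds shown here, no measured step exchanges exactly these two groups, so only the step from compound 1 to compound 2 bears on the question, and it shows that a change at this nitrogen can move the maximal response by a large amount in either direction. For compound 3 a step of a number 13 percentage points higher from compound 2 to compound 3 (beyond the scatter) in this assay is expected, upward, but with a wide band. The estimate for compound 3 in this assay is therefore 60%, within 35% to 85%.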

Compound 3, largest response reached (reported as efficacy), in percent of the reference or control that the assay uses: 76%
The estimate for compound 3 lay 16 percentage points below the measured number, and the stated range covers the measured number.
By their numbers in this assay, from the lowest: compound 2; then compounds 3 and 1 (each within the scatter of the next).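

Working notes on the amine nitrogen in a ring. In this assay the (trifluoromethyl)carbonyl group gives a second reading at this place, and the entry of this group brings a number 29 percentage points higher from compound 2 to compound 3 (beyond the scatter) so the low maximal response seen so far does not hold for every group on this nitrogen. With the carbonyl kept, trifluoromethyl on the carbonyl carbon gives a number 3 percentage points lower from compound 1 to compound 3 (within the scatter) so in this read-out two groups of different size and make-up on that carbon are not told apart, and the sulfur-bearing group alone stands lower among the three, although its sulfur never changes on its own in these steps. Nothing at hand bears on the reason for these differences.

Open, going by these compounds, is whether sulfur itself accounts for the lower response, a question that the oxygen counterpart of compound 2, with an isopropyl carbamate on the nitrogen, would settle directly. Also open, on these data alone, is whether the response holds with a plain acetyl group, a methanesulfonyl group or a simple alkyl chain on this nitrogen, where the carbonyl or the fluorine atoms are taken away.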